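The source may hold more compounds than are shown below. What is called first, only, known or untested is meant among the compounds shown, and "the series" means these compounds.

Measured so far:
- compound 1, `CC(C)Cc1cc(CNS(=O)(=O)c2cccc(Cl)c2)nn1-c1ccccc1`: 10900 nM
- compound 2, `O=C1c2[nH]nc(NS(=O)(=O)c3ccc4ccccc4c3)c2CCN1CC1CCNCC1`: 310 nM
- compound 3, `CC(C)Cc1cc(CNS(=O)(=O)c2ccccc2)nn1-c1ccccc1`: "not determined" (no result reported)

In a functional assay on HeLa cells for antagonist activity at 5-hydroxytryptamine receptor 6 (Homo sapiens), read by HTRF and cAMP accumulation, with stated times of 10 min and 30 min (on this read-out lower numbers stand for stronger inhibition and higher numbers for weaker inhibition), compound 1 gives 10900 nM and stands highest of the two numbers obtained. Compound 2, built on a different core, gives 310 nM, a gap to compound 1 that lies well beyond the scatter of the measurement. Compound 3 has no recorded value, so it adds nothing to the comparison.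

Compound 4, `CC(C)Cc1cc(CNS(=O)(=O)c2ccc3ccccc3c2)nn1-c1ccccc1`, keeps the core of compound 1 and differs from it in one place: naphthalen-2-yl in place of 3-chlorophenyl on a sulfonyl sulfur. For the measured compounds named here, no pair of measured compounds shows this exact exchange on the same core, so the size of the step has to be guessed. Going by the values given here, the only measured compound carrying a naphthalen-2-yl sulfonamide is compound 2 with 310 nM, but its core is not that of compound 1, so it serves only as a loose hint. The step from compound 1 to compound 4 is expected to be a 2.7-fold lower number from compound 1 to compound 4 (0.44 log units; beyond the scatter), a moderate move toward a lower number. For compound 4 the estimate is 4000 nM, with a range from 800 nM to 20000 nM.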

Compound 4, half-maximal inhibitory concentration: 3300 nM
Estimate against measurement, compound 4: 1.2-fold (0.08 log units) above; low and high end bracket the measured number.
By their numbers in this assay, from the lowest: compound 2; then compound 4; then compound 1.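

In this assay, for the compounds shown here, the change of 3-chlorophenyl to naphthalen-2-yl on a sulfonyl sulfur, with the core of compound 1 kept, gives a 3.3-fold lower number from compound 1 to compound 4 (0.52 log units; beyond the scatter) and is the first single change that can be read here. It shows that the group at this place can move the number, and that going from one six-membered aromatic ring to two, with the chlorine gone, brings a modest gain in inhibition rather than a loss.

Going by these compounds, compound 3, with a plain phenyl at this place, has no number, so the share of the chlorine and the share of the second ring cannot be told apart, and a group of another kind here, such as a carboxylic acid or an aminoethyl chain, remains open. No measurement at hand bears on why the number moves.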